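Rearranged acid side chain: exposure notes

This account rests on a few compounds, and the source may have more. Where it says the series, first, only, none or still open, it means among the compounds named here.

In an ADME assay on the whole organism (strain CD-1) for pharmacokinetics, with Mus musculus as the target, at a dose of 3 mg/kg by the intravenous route (on this read-out higher numbers stand for higher exposure at the dose given and lower numbers for lower exposure), compound 1 (`CN(Cc1ccccc1OCCC/C=C/C(=O)O)C(=O)c1ccc(-c2ccco2)cc1`) gives 750 ng.h/mL and compound 2 (`C/C(=C\CCCOc1ccccc1CN(C)C(=O)c1ccc(-c2ccco2)cc1)C(=O)O`) gives 1300 ng.h/mL with the two inside the usual scatter of each other. Compound 3 (`C/C(=C\COc1ccccc1CN(C)C(=O)c1ccc(-c2ccco2)cc1)CCC(=O)O`) carries 4-carboxy-2-methylbut-1-en-1-yl in place of 4-carboxypent-3-en-1-yl on a saturated chain carbon bound to an oxygen on an aromatic ring with the same atoms joined differently. Among the measured compounds shown here, the only measured step on this side chain, a 1.7-fold higher number from compound 1 to compound 2 (0.24 log units; within the scatter) for a different change, points to no direction here. No step beyond the scatter is therefore expected, and the estimated step is a 1.2-fold lower number from compound 2 to compound 3 (0.07 log units; within the scatter) in this assay for this pair. Compound 3 is estimated at 1100 ng.h/mL with an expected range from 450 ng.h/mL to 2600 ng.h/mL on this read-out.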

Compound 3, area under the concentration-time curve: 3300 ng.h/mL
For compound 3 the middle estimate is 3.0-fold (0.48 log units) below the measured one; the whole stated range lies below it.
By their numbers in this assay, from the lowest: compounds 1 and 2 (each within the scatter of the next); then compound 3.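

In this assay, exchanging 4-carboxypent-3-en-1-yl for 4-carboxy-2-methylbut-1-en-1-yl gives a 2.5-fold higher number from compound 2 to compound 3 (0.40 log units; beyond the scatter): the same atoms, joined differently, move the read-out beyond the scatter, which the earlier step on this side chain did not do. Measured against the 4-carboxybut-3-en-1-yl chain, the change is a 4.4-fold higher number from compound 1 to compound 3 (0.64 log units; beyond the scatter). Nothing available explains this difference.

As far as these compounds go, it remains open whether the higher number survives a longer chain on the same oxygen. From the compounds shown here alone, the effect of a tetrazole or an amide in place of the carboxylic acid also remains open.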